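The source may report more compounds than this note shows. Statements on the series, on what has been measured and on what is new or still open speak of the compounds shown alone.

Series notes. In an assay on CHO cells for displacement of a labelled ligand from adenosine receptor A3 (Homo sapiens), tested at 10 uM (a higher number here means more inhibition at the concentration tested (going by the name of the read-out), a lower number less inhibition), compound 1 `Nc1ncnc2c1ncn2[C@H]1C[C@H](CO)CO1` gives 7%, the lowest of the three numbers in hand. Compound 2 `CNC(=O)OC[C@@]1(O)CO[C@@H](n2cnc3c(N)ncnc32)[C@@H]1O` gives 26% in this assay, a number beyond the scatter above compound 1, while compound 3 `OC[C@]1(O)CO[C@@H](n2cnc3c(NCc4cccc(Cl)c4)ncnc32)[C@@H]1O` gives 44%, the furthest from compound 1 and also beyond the scatter. No step between two measured compounds that differ in one place is available, so nothing shown bears directly on a change of configuration alone. Compound 4 `Nc1ncnc2c1ncn2[C@H]1C[C@@H](CO)CO1` is the next case: the two compounds have the same atoms and bonds and differ only in configuration as drawn: 1 of 2 stereo elements differ; a stereocentre at a saturated ring carbon is drawn R in compound 1 and S in compound 4. A change of this kind is expected to be small, with no direction beyond the scatter, so the estimated step of a number 3 percentage points higher from compound 1 to compound 4 (within the scatter) is close to none. Compound 4 is therefore estimated at 10%, with a range from 0% to 25%.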

Compound 4, a percentage reported as inhibition, at one concentration (the size of the read-out at that concentration, not a potency): 31%
Beside the measured number, compound 4's estimate is 21 percentage points below it; measured number above the stated range.
By their numbers in this assay, from the lowest: compound 1; then compounds 2 and 4 (each within the scatter of the next); then compound 3.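

In this assay, redrawing a stereocentre at a saturated ring carbon from R to S gives a number 24 percentage points higher from compound 1 to compound 4 (beyond the scatter). For the compounds shown here, this is the first step that isolates a single place, and it shows that configuration at this carbon alone can move the number beyond the scatter. The reading of this step as a configuration effect rests on: the fact that compounds 1 and 4 differ only in the configuration as drawn

The compounds shown leave open how the other stereo element bears on this number. Also open, going by these compounds, is whether the S drawing still gives the higher number once the hydroxyl is replaced by an amine or a carboxylic acid.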